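Side-chain swap on compound 1: spiro amine to fluorophenoxy

The source may report more compounds than this note shows. Statements on the series, on what has been measured and on what is new or still open speak of the compounds shown alone.

Within the data shown here, compound 1 `COc1ccc2[nH]c(C(=O)N3CC(=O)N(Cc4ccccc4)[C@@H](CN4CCC5(CC4)CC5)C3)cc2c1` holds the highest of the three numbers so far in an ADME assay on microsomes from liver (Homo sapiens) for metabolic stability, with a stated time of 30 min, tested at 1 uM (a higher number here means that the compound lasts longer, a lower number that the compound disappears faster), giving 0.867 h. The nearest of the other two is compound 2 `COc1ccc2[nH]c(C(=O)N3CC(=O)N(Cc4ccc[nH]4)[C@@H](Cc4ccccc4)C3)cc2c1`, which in this assay gives 0.267 h, a gap beyond the usual scatter. Furthest is compound 3 `COc1cccc(CN2C(=O)CN(C(=O)c3cc4cc(OC)ccc4[nH]3)C[C@@H]2CCc2ccccc2)c1`, which in this assay gives 0.12 h, again beyond the scatter. Among the measured compounds shown here, both of these carry an aromatic side chain on the ring carbon where compound 1 carries its spiro amine, and both sit well under compound 1; no compound so far goes against that ordering.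

Compound 4 `COc1ccc2[nH]c(C(=O)N3CC(=O)N(Cc4ccccc4)[C@@H](COc4ccc(F)cc4)C3)cc2c1` differs from compound 1 by a group of 8 heavy atoms (6 carbon, 1 oxygen, 1 fluorine; one six-membered aromatic ring of carbon only) in place of a group of 8 heavy atoms (7 carbon, 1 nitrogen; one three-membered non-aromatic ring of carbon only, one six-membered non-aromatic ring with 1 hetero atom), on a saturated chain carbon bound to a saturated ring carbon. For the measured compounds named here, no measured pair shows this exact change, so the size of the step is uncertain. The expectation rests on compound 2 giving 0.267 h and compound 3 giving 0.12 h with aromatic side chains at the same place: a downward step from compound 1 to compound 4 is expected, probably beyond the scatter but short of the full drop seen for compound 3, estimated as a 2.2-fold lower number from compound 1 to compound 4 (0.34 log units; beyond the scatter). For compound 4 in this assay the estimate is 0.4 h, expected to lie between 0.15 h and 1 h.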

Compound 4, half-life: 0.317 h
The estimate for compound 4 lay 1.3-fold (0.10 log units) above the measured number; low and high end bracket the measured number.
By their numbers in this assay, from the lowest: compound 3; then compounds 2 and 4 (each within the scatter of the next); then compound 1.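

Among these compounds, on a saturated chain carbon bound to a saturated ring carbon, 4-fluorophenoxy in place of the spiro amine group of compound 1 gives, in this assay, a 2.7-fold lower number from compound 1 to compound 4 (0.44 log units; beyond the scatter) and so provides the only step at this position between compounds that differ in one place. The two groups match in heavy atoms, hydrogen-bond donors, hydrogen-bond acceptors and net charge as counted, so this step comes with a change in atom types and ring types, not with a change in those counts. Nothing measured here gives a cause for the step.

A single pair cannot separate the loss of the spiro amine group from the arrival of 4-fluorophenoxy, and it leaves open whether the fluorine plays any part in the step. Piperidine or morpholine at this place, and plain phenoxy with the rest of compound 1 unchanged, would show whether the step follows the ring nitrogen, the aromatic ring or the fluorine.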